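The source may report more compounds than this note shows. Statements on the series, on what has been measured and on what is new or still open speak of the compounds shown alone.

Measured in a functional assay on MCF7 cells (Homo sapiens) for cytotoxicity, read by MTT assay, with a stated time of 96 h; a lower number here means a stronger inhibitor, a higher number a weaker inhibitor:
- compound 1 `COc1cc(C(=O)c2cn(-c3cccc(C)c3)cc2-c2ccccc2F)cc(OC)c1OC`: 190 nM
- compound 2 `COc1cc(C(=O)c2cn(-c3ccc(C)cc3)cc2-c2ccccc2F)cc(OC)c1OC`: 44 nM

Of these two numbers, compound 2 holds the lower, and the gap lies beyond the scatter. The next compound is compound 3 `COc1cc(C(=O)c2cn(-c3ccc(F)cc3)cc2-c2ccccc2F)cc(OC)c1OC`, which differs from compound 2 as follows: fluoro in place of methyl on an aromatic carbon. In words, this is 4-methylphenyl to 4-fluorophenyl.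

For the measured compounds named here, one measured step bears on this change: a 4.3-fold lower number from compound 1 to compound 2 (0.64 log units; beyond the scatter). Going by the values given here, it is modest and concerns the same aryl group, but it moves the methyl rather than replacing it, so no measured step shows what fluoro does in this assay. The direction therefore remains uncertain. Among the compounds with values here, compound 2, at 44 nM, is the lower of only two values, so a small rise is expected rather than a further drop. The expected change is a 1.4-fold higher number from compound 2 to compound 3 (0.13 log units; within the scatter), probably within the scatter. For compound 3 the estimated value is 60 nM, with an expected range of 20 nM to 190 nM.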

Compound 3, half-maximal inhibitory concentration: 39 nM
Compound 3: the middle estimate sits 1.5-fold (0.19 log units) above what was measured; the range from low to high includes it.
By their numbers in this assay, from the lowest: compounds 3 and 2 (each within the scatter of the next); then compound 1.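

Fluoro and methyl on this aromatic carbon, para to a large group, cannot be told apart in this assay: the exchange gives a 1.1-fold lower number from compound 2 to compound 3 (0.05 log units; within the scatter). The 4-fluorophenyl group also stands clear of the 3-methylphenyl group, with a 4.9-fold lower number from compound 1 to compound 3 (0.69 log units; beyond the scatter), so compounds 2 and 3 both read lower than compound 1 whichever of the two groups sits at this place. No measurement on hand accounts for the two groups reading alike.

Still open, on these data alone, is how an amine, a carboxylic acid or a longer chain in place of the fluoro would read in this assay, and whether the unsubstituted phenyl would match compounds 2 and 3. Also open, as far as these compounds go, is whether 3-fluorophenyl would read as far from 4-fluorophenyl as the 3-methylphenyl group does.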